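The compounds below may be only part of what the source reports. "The series", "measured", "known", "first", "only" and "open" are said of these compounds alone.

Three compounds share one core and differ in the substituent on the saturated ring. Compound 1 `Cn1ncc(Cl)c1-c1cc(C(=O)NC2CNCCC2c2ccc(C(F)(F)F)cc2)oc1Cl` gives 7.2 nM in an assay for inhibition of RAC-alpha serine/threonine-protein kinase (Homo sapiens), read by HTRF, with a stated time of 1 h; a lower number here means a stronger inhibitor, a higher number a weaker inhibitor. Compound 2 `Cn1ncc(Cl)c1-c1cc(C(=O)N[C@@H]2CN[C@H](CC(O)CO)C[C@H]2c2ccc(F)c(F)c2)oc1Cl` gives 3.31 nM in this assay, and compound 3 `Cn1ncc(Cl)c1-c1cc(C(=O)N[C@@H]2CN[C@H](CCN3CCCCC3)C[C@H]2c2ccc(Cl)c(Cl)c2)oc1Cl` gives 5.65 nM in this assay; all three numbers lie within the usual scatter of one another, so none of them can be set apart from the rest. Compound 4 `Cn1ncc(Cl)c1-c1cc(C(=O)N[C@@H]2CN[C@H](CC(=O)NC3CCC3)C[C@H]2c2ccc(Cl)c(Cl)c2)oc1Cl` has not yet been measured. It differs from compound 3 in one place: cyclobutylcarbamoyl in place of (piperidin-1-yl)methyl on a saturated chain carbon bound to a saturated ring carbon. Because compound 1 gives 7.2 nM and compound 2 gives 3.31 nM and compound 3 gives 5.65 nM while the substituent at this place varies widely among them, the expected step of a 1.4-fold higher number from compound 3 to compound 4 (0.15 log units; within the scatter) is small, if anything toward a higher number. Compound 4 is estimated at 8 nM, with a range from 3 nM to 25 nM.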

Compound 4, half-maximal inhibitory concentration: 7.98 nM
The estimate for compound 4 lay 1.0-fold (0.00 log units) above the measured number; measured number inside the range.
By their numbers in this assay, from the lowest: compounds 2, 3, 1 and 4 (each within the scatter of the next, the first and the last beyond it).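

In this assay, cyclobutylcarbamoyl in place of (piperidin-1-yl)methyl gives a 1.4-fold higher number from compound 3 to compound 4 (0.15 log units; within the scatter) on a saturated chain carbon bound to a saturated ring carbon. For the compounds shown here, this is the first pair that differs in one place only, and it shows that exchanging the six-membered ring with its nitrogen for a four-membered carbon ring, a carbonyl and an amide hydrogen leaves the number within the scatter. Nothing available explains this result. From the compounds shown here alone, whether a carboxylic acid, a primary amine or a longer chain at this place would also stay within the scatter remains open.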